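Pyridinyloxy Variation on a Cyanopyridinone Scaffold

The compounds below may be only part of what the source reports. "The series", "measured", "known", "first", "only" and "open" are said of these compounds alone.

Measured compounds:
- compound 1 `COc1ccccc1-c1ccn(CCC(C)C)c(=O)c1C#N`: 120%
- compound 2 `CC(C)CCn1ccc(-c2ccc(Oc3ccccn3)cc2)c(C#N)c1=O`: 249%
- compound 3 `Cc1cc(Oc2ccc(-c3ccn(CC4CCC4)c(=O)c3C#N)cc2)ccn1`: 233%

In a functional assay on CHO cells for positive allosteric modulation of metabotropic glutamate receptor 2 (Homo sapiens), read by scintillation counting and GTPgammaS binding, with a stated time of 30 min (on this read-out higher numbers stand for larger maximal responses and lower numbers for smaller maximal responses), compound 1 gives 120%, compound 2 gives 249% and compound 3 gives 233%. Compound 2 stands highest of the three: its nearest neighbour is compound 3, which lies lower by a margin beyond the scatter, and compound 1 lies furthest below it, also beyond the scatter. Compound 2 and compound 3 share the aryloxy-substituted phenyl group on the core and both sit well above compound 1, which carries a methoxyphenyl instead.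

Compound 4 `Cc1ncccc1Oc1ccc(-c2ccn(CCC(C)C)c(=O)c2C#N)cc1` has not yet been measured. It differs from compound 2 in one place:
2-methylpyridin-3-yl in place of pyridin-2-yl on an oxygen on an aromatic ring
Going by the values given here, no measured pair shows this exact change. Compound 3 carries a methyl-bearing pyridinyl on the same oxygen and its value in this assay lies close to, though below, that of compound 2, so a small step from compound 2 to compound 4 is expected, a number 19 percentage points lower from compound 2 to compound 4 (beyond the scatter), probably not beyond the scatter. Compound 4 is estimated to give 230% in this assay, with a range from 170% to 280%.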

Compound 4, largest response reached (Emax), in percent of the reference or control that the assay uses: 256%
For compound 4 the middle estimate is 26 percentage points below the measured one; low and high end bracket the measured number.
By their numbers in this assay, from the lowest: compound 1; then compound 3; then compounds 2 and 4 (each within the scatter of the next).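

In this assay, 2-methylpyridin-3-yl in place of pyridin-2-yl on the oxygen gives a number 7 percentage points higher from compound 2 to compound 4 (within the scatter), so compound 2 and compound 4 cannot be told apart on this read-out. Going by these compounds alone, no earlier pair differed in one place only, so this step is the first direct reading of a change at this oxygen. It shows that this position can carry either pyridinyl group, including the one with 7 heavy atoms in place of 6, with no step beyond the scatter. Nothing at hand explains why the two groups read alike.

Going by these compounds, how pyridin-3-yl without the methyl would read remains open, so the methyl and the change from the 2-yl to the 3-yl linkage cannot be separated. Also open, on these data alone, is how a phenyl, or a pyridinyl bearing an amine, would read on the same oxygen.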